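The compounds below may be only part of what the source reports. "The series", "measured", "known", "first", "only" and "open" are said of these compounds alone.

Two compounds have been measured so far:

compound 1, `COc1cc(C(=O)N/N=C/c2ccc(F)c(F)c2)cc(OC)c1OC`: 51.9%
compound 2, `COc1cc(C2=NN(C(C)=O)C(c3cc(Cl)cc(Cl)c3)O2)cc(OC)c1OC`: 6.6%

Both were tested in a functional assay on BGC-823 cells (Homo sapiens) for antiproliferative activity, read by MTT assay, tested at 5 uM; a higher number here means a stronger effect of the compound at the concentration tested, a lower number a weaker effect. Compound 1 stands highest of the two numbers: in this assay compound 1 gives 51.9%, while compound 2 gives 6.6%, a gap well beyond the usual scatter of the measurement. Since compound 2 differs from compound 1 in more than one place, its lower value cannot be tied to any single change.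

Compound 3, `COc1cc(C(=O)N/N=C/c2cccc(F)c2)cc(OC)c1OC`, has not yet been measured. It differs from compound 1 as hydrogen in place of fluoro on an aromatic carbon; read one bond further out, the change is 3,4-difluorophenyl to 3-fluorophenyl. Going by the values given here, no measured pair in this set shows this change, so there is no step to lean on, and the removal of a single fluorine is a small alteration. For compound 3 the step of a number 6.9 percentage points lower from compound 1 to compound 3 (within the scatter) is expected to be small, most likely a slight downward shift that stays within the scatter. Compound 3 is therefore estimated at 45%, with a likely range from 25% to 65%.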

Compound 3, a percentage reported as inhibition, at one concentration (the size of the read-out at that concentration, not a potency): 44.8%
The estimate for compound 3 lay 0.2 percentage points above the measured number, and the stated range covers the measured number.
By their numbers in this assay, from the lowest: compound 2; then compounds 3 and 1 (each within the scatter of the next).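

In this assay, going by these compounds alone, the pair of compound 1 and compound 3 gives the first step in this set that can be read in one place: a number 7.1 percentage points lower from compound 1 to compound 3 (within the scatter). The change from 3,4-difluorophenyl to 3-fluorophenyl, with hydrogen taking the place of the fluoro group on an aromatic carbon ortho to the other fluoro group and para to a large group, therefore does not separate the two compounds at the concentration tested, and a fluoro group at this position is not needed for a read-out of this size, as compound 3 still gives 44.8% in this single comparison. Nothing measured here offers an explanation for this result.

The compounds shown leave open how a chloro group, a methoxy group, an amine or a carboxylic acid would read at this position, and whether the remaining fluoro group matters, as an unsubstituted phenyl ring does not stand among them. The steps from compound 2 to compound 1 and compound 3 cannot be read, as compound 2 differs from both in more than one place.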